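A few compounds are considered here, and "the series" means these few. Any claim that something is new, unique, unknown or untested is made for them only; others in the source may bear on it.

In a functional assay on HCT-116 cells (Homo sapiens) (a higher number here means a weaker inhibitor, a lower number a stronger inhibitor), the measurements so far are:

Compound 1 `COc1cc(NC(C)CCCNC(=O)NCCCCCO)c2ncccc2c1`: 29000 nM
Compound 2 `COc1cc(NC(C)CCCNC(=O)NCCNC(=O)NCCCC(C)Nc2cc(OC)cc3cccnc23)c2ncccc2c1`: 15000 nM
Compound 3 `COc1cc(N2C(=O)NCCCC2C)c2ncccc2c1`: > 100000 nM (a limit of the assay, not a number)

For the measured compounds named here, compound 1 lies within the usual scatter of compound 2, and these two are the only true numbers so far. Compound 4 `CCOC(=O)NCCCC(C)Nc1cc(OC)cc2cccnc12` has not yet been measured. It carries ethoxy in place of (5-hydroxypentyl)amino on a carbonyl carbon. Going by the values given here, no measured step shows what this swap does, so the expectation is loose: no step beyond the scatter in this assay, and if anything a slightly weaker inhibitor. The expected step is a 1.2-fold higher number from compound 1 to compound 4 (0.08 log units; within the scatter). Compound 4 is estimated at 35000 nM, with an expected range from 12000 nM to 90000 nM.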

Compound 4, half-maximal inhibitory concentration: 28000 nM
For compound 4 the middle estimate is 1.3-fold (0.10 log units) above the measured one; measured number inside the range.
By their numbers in this assay, from the lowest: compounds 2, 4 and 1 (each within the scatter of the next). At a limit, above all of these: compound 3.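

In this assay, the first step read at this place, on a carbonyl carbon, is a 1.0-fold lower number from compound 1 to compound 4 (0.02 log units; within the scatter). For this pair, then, the (5-hydroxypentyl)amino group with its hydrogen-bond donors can give way to the smaller ethoxy while the two numbers stay within the scatter. No measurement shown here gives a reason for this result. Still open, as far as these compounds go, is whether a simple amine on this carbonyl carbon, or a longer chain ending in a carboxylic acid, would give a number beyond the scatter from compound 1.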